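Shortening the triazole nitrogen substituent to a cyclobutyl ring

The compounds below may be only part of what the source reports. "The series", "measured", "known", "first", "only" and "open" are said of these compounds alone.

Among the compounds with values here, the three compounds measured so far share one core and differ only in the group carried on an aromatic nitrogen of the triazole. In a functional assay on HT-29 cells (Homo sapiens) for inhibition, read by luminescence and CellTiter-Glo, with a stated time of 24 h (a higher number here means that more compound is needed for the effect, a lower number that less compound is needed), compound 1 `CC(C)Cn1nc(C(=O)N[C@H]2COc3ccccc3N(C)C2=S)nc1Cc1ccccc1` gives 1230 nM, compound 2 `CC(C)CCn1nc(C(=O)N[C@H]2COc3ccccc3N(C)C2=S)nc1Cc1ccccc1` gives 3640 nM, and compound 3 `CN1C(=S)[C@@H](NC(=O)c2nc(Cc3ccccc3)n(CCC(F)(F)F)n2)COc2ccccc21` gives 1550 nM. Compound 2 therefore stands highest of the three numbers: a 3.0-fold higher number from compound 1 to compound 2 (0.47 log units; beyond the scatter), and a 2.3-fold lower number from compound 2 to compound 3 (0.37 log units; beyond the scatter), while compound 1 and compound 3 sit within the scatter of one another (a 1.3-fold higher number from compound 1 to compound 3 (0.10 log units; within the scatter)).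

Compound 4 `CN1C(=S)[C@@H](NC(=O)c2nc(Cc3ccccc3)n(C3CCC3)n2)COc2ccccc21` takes the same step again: cyclobutyl in place of isopentyl on an aromatic nitrogen. Within the data shown here, both steps that changed this substituent from the isopentyl of compound 2 moved the number downward by modest, beyond-scatter amounts, and no measured step from compound 2 points upward. A modest decrease in this assay is therefore expected for compound 4, estimated as a 2.6-fold lower number from compound 2 to compound 4 (0.41 log units; beyond the scatter). Compound 4 is expected to give about 1400 nM in this assay, in a range from 600 nM to 3500 nM.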

Compound 4, half-maximal effective concentration: 181 nM
The estimate for compound 4 lay 7.7-fold (0.89 log units) above the measured number; measured number outside the range, below it.
By their numbers in this assay, from the lowest: compound 4; then compounds 1 and 3 (each within the scatter of the next); then compound 2.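

Within the data shown here, putting a ring on this aromatic nitrogen produces the first large step at the position: in this assay, cyclobutyl in place of isopentyl brings a 20-fold lower number from compound 2 to compound 4 (1.30 log units; beyond the scatter), whereas the steps among the three open chains were modest or within the scatter. The drop does not depend on one particular chain, as cyclobutyl also gives an 8.6-fold lower number from compound 3 to compound 4 (0.93 log units; beyond the scatter) and a 6.8-fold lower number from compound 1 to compound 4 (0.83 log units; beyond the scatter). Compound 4 therefore stands lowest of the four, with its steps to all the others beyond the scatter, so the substituent here can shift this number much further than the open chains indicated.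

Nothing measured here accounts for the size of this difference. The compounds shown leave open whether it belongs to the four-membered carbon ring specifically or would also appear with cyclopropyl, cyclopentyl or an oxetane on the same nitrogen.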